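This account rests on a few compounds, and the source may have more. Where it says the series, first, only, none or still open, it means among the compounds named here.

Compound 1, `Cc1c(C(=O)Nc2ccc(Oc3ncnc4[nH]cc(-c5ccccc5)c34)c(F)c2)c(=O)c2c(Cl)cccc2n1C`: > 10000 nM
Compound 2, `Cc1c(C(=O)Nc2ccc(Oc3ncnc4[nH]cc(-c5ccccc5)c34)c(F)c2)c(=O)c2cc(F)ccc2n1C`: > 10000 nM
Compound 3, `CCc1ccc2c(c1)c(=O)c(C(=O)Nc1ccc(Oc3ncnc4[nH]cc(-c5ccccc5)c34)c(C)c1)c(C)n2C`: 1120 nM

In an assay on isolated protein for inhibition of tyrosine-protein kinase receptor UFO (Homo sapiens), read by FRET and Z'-LYTE, with a stated time of 1.5 h (a higher number here means a weaker inhibitor, a lower number a stronger inhibitor), compound 2 gives only a limit of the assay, > 10000 nM, and no number. Compound 1 likewise reaches only a limit in this assay, > 10000 nM. Compound 3 gives a number in this assay, 1120 nM. Within the data shown here, compound 2 thus stands at the limit of > 10000 nM in this assay, at which 2 of the 3 values shown sit, and since no two measured compounds differ in a single place, no step between measured compounds can be read off.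

Compound 4, `Cc1c(C(=O)Nc2ccc(Oc3ncnc4[nH]cc(-c5ccccc5)c34)c(F)c2)c(=O)c2cc(C(C)(C)C)ccc2n1C`, has not yet been measured in this assay. It differs from compound 2 by tert-butyl in place of fluoro on an aromatic carbon.

Compound 3, which carries an ethyl on the fused ring and a methyl on the central ring, shows a number where compound 2 shows only a limit; nothing more than that can be taken from the pair. Starting from a limit, the size of the step cannot be anchored, and a further limit for compound 4 would not be surprising. The step that this estimate implies, an at least 2.5-fold lower number from compound 2 to compound 4 (0.39 log units; beyond the scatter), is expected to run toward stronger inhibition, if at all, by more than the scatter. For compound 4 in this assay an inhibitory concentration of about 4000 nM is expected, between 1000 nM and 15000 nM.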

Compound 4, half-maximal inhibitory concentration: 42 nM
The estimate for compound 4 lay 95-fold (1.98 log units) above the measured number; the whole stated range lies above it.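

In this assay, the aromatic carbon that is meta to a fused ring and para to a fused ring proves highly sensitive to its substituent, with tert-butyl in place of fluoro giving an at least 230-fold lower number from compound 2 to compound 4 (2.37 log units; beyond the scatter). Among these compounds, this is the first change at a single place that can be read, and it shows that this position accepts 4 heavy atoms where fluoro has 1, with a measured number rather than a limit as the result. Compound 2 reaches only a limit of the assay, so the step has a lower bound and no exact size: the limit of > 10000 nM in this assay, at which 2 of the 4 values shown sit.

The compounds shown leave open whether the gain is specific to tert-butyl, or whether an isopropyl, a methoxy or an amine on the same carbon would give a similar number. They also leave open what lies behind the step, and whether the same exchange would have a comparable effect on the core of compound 3.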